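This account rests on a few compounds, and the source may have more. Where it says the series, first, only, none or still open, it means among the compounds named here.

Compound 2 `O=C(Nc1cc(Oc2ccc(Nc3nccc4[nH]cc(-c5ccc(F)cc5)c(=O)c34)cc2F)ccn1)C1CC1`: 81.8%
Compound 1 `O=C(Nc1cc(Oc2ccc(Nc3nccc4[nH]cc(-c5ccc(F)cc5)c(=O)c34)cc2F)ccn1)C1CCC1`: 52.8%

Among the measured compounds shown here, in a functional assay on MKN-45 cells (Homo sapiens) for antiproliferative activity, read by MTT assay, with a stated time of 72 h, tested at 10 uM (a higher number here means more inhibition at the concentration tested (going by the name of the read-out), a lower number less inhibition), compound 2 gives the higher of the two numbers; compound 1 gives 52.8%, and the only measured step, a number 29 percentage points higher from compound 1 to compound 2 (beyond the scatter), exchanges one small ring for another on a carbonyl carbon. Compound 3 `Cn1cc(-c2ccc(F)cc2)c(=O)c2c(Nc3ccc(Oc4ccnc(NC(=O)C5CC5)c4)c(F)c3)nccc21` differs from compound 2 by methyl in place of hydrogen on an aromatic nitrogen. For the measured compounds named here, no measured step changes anything on the shared core, so nothing here bears directly on this change, and no step beyond the scatter is expected: a number 9.8 percentage points lower from compound 2 to compound 3 (within the scatter). Compound 3 is estimated at 72%, within 35% to 92%.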

Compound 3, a percentage reported as inhibition, at one concentration (the size of the read-out at that concentration, not a potency): 30.9%
Compound 3: middle estimate off by 41.1 percentage points, on the high side; the whole stated range lies above it.
By their numbers in this assay, from the lowest: compound 3; then compound 1; then compound 2.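

In this assay the change of methyl in place of hydrogen on the aromatic nitrogen gives a number 50.9 percentage points lower from compound 2 to compound 3 (beyond the scatter) and shows that the core is sensitive at this position. The earlier step changed only the small ring on the carbonyl carbon, so it could not show this. Nothing available explains why one added carbon costs so much inhibition.

One methyl compound cannot show whether any group on this nitrogen lowers inhibition. An ethyl group or a longer chain ending in an amine could behave differently.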